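The compounds below may be only part of what the source reports. "The series", "measured", "known", "first", "only" and "open" are said of these compounds alone.

Measured in an ADME assay on Vero cells (Chlorocebus sabaeus) for cytotoxicity, read by XTT assay, with a stated time of 72 h; a lower number here means that less compound is tolerated, a higher number that more compound is tolerated:

- compound 1 `CC1=C(C(=O)Nc2ccccc2Cl)C(c2ccccc2Cl)NC(=S)N1`; compound 1 gives > 100000 nM, which is a limit of the assay.
- compound 2 `CC1=C(C(=O)Nc2ccc(F)cc2)C(c2ccccc2)NC(=O)N1`; compound 2 gives > 100000 nM, again a limit of the assay.
- compound 3 `CC1=C(C(=O)Nc2ccccc2Cl)C(c2ccccc2Cl)NC(=O)N1`; compound 3 is reported as "non-toxic" (no number reported), with no number attached.

Compound 3 therefore stands without a single number in this assay. The only orientation comes from the limit of > 100000 nM in this assay, at which 2 of the 3 values shown sit, and compound 3 is described in the same non-toxic terms as those two. Within the data shown here, no step between measured compounds that differ in one place is available, so no measured change in this assay can be quoted.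

Compound 4 `CC1=C(C(=O)Nc2ccccc2Cl)C(c2ccc(Br)cc2)NC(=O)N1` is the next member. It differs from compound 3 by 4-bromophenyl in place of 2-chlorophenyl on a saturated ring carbon. Across the three measured compounds, changes of the aryl groups at the amide and at the saturated ring carbon left every value at or beyond the tolerated range, and compound 1 and compound 2 both sit at the limit. The expectation for compound 4 is accordingly no step beyond the scatter in this assay, in either direction. Compound 4 is estimated at 100000 nM, with a range from 30000 nM to 300000 nM, most probably reported only as a limit.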

Compound 4, half-maximal cytotoxic concentration: > 100000 nM
Compound 4 ended at the assay's limit (the forecaster's own chance of this, stated with the estimate: 80%); the middle value sits exactly at the limit.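

Compound 4 gives > 100000 nM, which is a limit of the assay. Among these compounds, compound 3 carries no number, so no step between the two can be read in this assay. The compounds shown leave open where any half-maximal cytotoxic concentration lies and whether the aryl groups change it: the limit of > 100000 nM in this assay, at which 3 of the 4 values shown sit.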